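The compounds below may be only part of what the source reports. "The series", "measured", "known", "first", "only" and "open" are said of these compounds alone.

Compound 1 `Oc1cccc(-c2cc(-c3ccccc3)cc(-c3ccccc3)n2)c1`: 9950 nM
Compound 2 `Oc1cccc(-c2cc(-c3ccccc3)cc(-c3cccs3)n2)c1`: 10900 nM
Compound 3 `Oc1ccc(-c2cc(-c3ccccc3)cc(-c3cccs3)n2)cc1`: 12500 nM

All three compounds were tested in a functional assay on HCT-15 cells (Homo sapiens) for cytotoxicity, read by ELISA, with a stated time of 2 days; a higher number here means a weaker inhibitor, a lower number a stronger inhibitor. Compound 3 stands level with the others, since its value lies within the usual scatter of both compound 1 and compound 2, and the three cannot be ranked.

The next compound, compound 4 `Oc1ccc(-c2cc(-c3ccccc3)cc(-c3ccc(O)cc3)n2)cc1`, differs from compound 3 in one place, next to the ring nitrogen: 4-hydroxyphenyl in place of thiophen-2-yl on an aromatic carbon. Put simply, this is 4-hydroxyphenyl in place of thiophen-2-yl on an aromatic carbon.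

Among the measured compounds shown here, two measured steps bear on this change. Putting thiophen-2-yl in place of phenyl at this same position gave a 1.1-fold higher number from compound 1 to compound 2 (0.04 log units; within the scatter). Putting 4-hydroxyphenyl in place of 3-hydroxyphenyl on the other side of the core gave a 1.1-fold higher number from compound 2 to compound 3 (0.06 log units; within the scatter). Neither step left the scatter, so the evidence points to a flat series. However, no measured compound carries two hydroxyphenyl groups, so this expectation is uncertain and the range is kept wide.

In this assay, no change beyond the scatter is expected, and the estimate is a 1.0-fold lower number from compound 3 to compound 4 (0.02 log units; within the scatter). The expected value for compound 4 is 12000 nM, with an estimated range from 4500 nM to 35000 nM.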

Compound 4, half-maximal inhibitory concentration: 3000 nM
The estimate for compound 4 lay 4.0-fold (0.60 log units) above the measured number; measured number below the stated range.
By their numbers in this assay, from the lowest: compound 4; then compounds 1, 2 and 3 (each within the scatter of the next).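

In this assay, 4-hydroxyphenyl in place of thiophen-2-yl on the aromatic carbon next to the ring nitrogen gave a 4.2-fold lower number from compound 3 to compound 4 (0.62 log units; beyond the scatter), the only step shown here that lies beyond the scatter. This position is therefore not indifferent to the group it carries, even though the earlier exchange there, a 1.1-fold higher number from compound 1 to compound 2 (0.04 log units; within the scatter), stayed within the scatter. The entering group differs from thiophen-2-yl in two counted ways, adding a hydrogen-bond donor and replacing a five-membered aromatic ring with a six-membered one, and no measurement at hand says why the number fell or which of these differences matters.

The compounds shown leave open whether the hydroxyl group itself goes with the lower number, as the only comparison at this position that lacks it, between phenyl and thiophen-2-yl, involves no hydroxyl at all. Also open, as far as these compounds go, is whether a methoxy group or an amine in place of that hydroxyl on the ring would keep the lower number or return it to the level of compound 3.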